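The source may hold more compounds than are shown below. What is called first, only, known or untested is meant among the compounds shown, and "the series" means these compounds.

Of the compounds shown here, three have so far been measured in an assay on isolated protein for inhibition of RAC-alpha serine/threonine-protein kinase (Homo sapiens); on this read-out lower numbers stand for stronger inhibition and higher numbers for weaker inhibition. Compound 1 `CCOCCN(C[C@@H](O)CN1CCCC2(CCN(c3ncnc4[nH]cc(C)c34)CC2)C1)S(=O)(=O)c1c(C)cccc1C` gives 41 nM in this assay. Compound 2 `CCOCCN(C[C@@H](O)CN1CCC2(CCN(c3ncnc4[nH]nc(C)c34)C2)C1)S(=O)(=O)c1c(C)cccc1C` gives 17 nM in this assay. Compound 3 `CCOCCN(C[C@@H](O)CN1CCCC2(CCN(c3ncnc4ccccc34)C2)C1)S(=O)(=O)c1c(C)cccc1C` gives 38 nM in this assay. Among these three, the number for compound 3 is the second highest. Its nearest neighbour is compound 1, and the gap between them lies within the usual scatter, so the two cannot be told apart. The gap to compound 2 lies beyond the scatter, and compound 2 has the lower number, so compound 2 inhibits more strongly than compound 3.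

Compound 4 `CCOCCN(C[C@@H](O)CN1CCCC2(CCN(c3ncncc3C3CC3)C2)C1)S(=O)(=O)c1c(C)cccc1C` has not yet been measured. It differs from compound 3 in one place: 5-cyclopropylpyrimidin-4-yl in place of quinazolin-4-yl on an amine nitrogen in a ring. Going by the values given here, no measured pair among compounds 1, 2 and 3 shows a step of this kind, so there is no direct guide. All three measured compounds, with different groups on that amine nitrogen, fall in a fairly narrow band. The step from compound 3 to compound 4 is therefore expected to be small, likely toward weaker inhibition and close to the scatter, as a 1.7-fold higher number from compound 3 to compound 4 (0.23 log units; within the scatter) shows. Compound 4 is expected to give about 65 nM in this assay, within a range from 20 nM to 220 nM.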

Compound 4, half-maximal inhibitory concentration: 12 nM
Compound 4: middle estimate off by 5.4-fold (0.73 log units), on the high side; measured number below the stated range.
By their numbers in this assay, from the lowest: compounds 4 and 2 (each within the scatter of the next); then compounds 3 and 1 (each within the scatter of the next).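

In this assay, exchanging quinazolin-4-yl for 5-cyclopropylpyrimidin-4-yl on the amine nitrogen of the five-membered ring gives a 3.2-fold lower number from compound 3 to compound 4 (0.50 log units; beyond the scatter), a modest step that lies beyond the usual scatter. This shows that the six-membered aromatic ring of carbon only, found in quinazolin-4-yl, can be given up at this position without loss of inhibition, provided a cyclopropyl group is present on the remaining six-membered aromatic ring with 2 hetero atoms, and that this position responds measurably to the group placed there. The compounds shown offer no independent measurement that explains the direction of this step.

From the compounds shown here alone, the step combines two changes, the loss of one ring and the arrival of cyclopropyl, so the share of each remains unknown; a plain pyrimidin-4-yl group, or a pyrimidine carrying a methyl or an ethyl group in place of cyclopropyl, would help to separate them. Going by these compounds, it also remains open whether the same exchange would give a similar step on the cores of compound 1 and compound 2.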